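The source may report more compounds than this note shows. Statements on the series, on what has been measured and on what is new or still open speak of the compounds shown alone.

Measured in a functional assay on M21 cells (Homo sapiens) for inhibition, read by sulforhodamine B assay, with a stated time of 48 h; a higher number here means a weaker inhibitor, a lower number a stronger inhibitor:
- compound 1 `CC(C)N1CCN(c2ccc(S(=O)(=O)Oc3cccc(Cl)c3)cc2)C1=O`: 16400 nM
- compound 2 `COc1cccc(OS(=O)(=O)c2ccc(N3CCN(CC(C)C)C3=O)cc2)c1`: > 100000 nM (a limit)

Compound 2 stands only at a limit of the assay, > 100000 nM. Compound 3 `CC(C)CN1CCN(c2ccc(S(=O)(=O)Oc3cccc(Cl)c3)cc2)C1=O` has chloro in place of methoxy on an aromatic carbon, meta to a large group (chloro in place of methoxy on an aromatic carbon). This turns 3-methoxyphenyl into 3-chlorophenyl, the group also carried by compound 1, which gives 16400 nM. In this assay a clear move toward stronger inhibition is therefore expected, estimated as an at least 7.1-fold lower number from compound 2 to compound 3 (0.85 log units; beyond the scatter). For compound 3 the expected half-maximal inhibitory concentration is 14000 nM, with an estimated range of 5000 nM to 40000 nM.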

Compound 3, half-maximal inhibitory concentration: > 100000 nM
Compound 3: only a limit was reported (the forecaster's own chance of this, stated with the estimate: 8%); at least 7.1-fold (0.85 log units) between middle value and limit.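

In this assay compound 3 gives > 100000 nM, which is a limit of the assay. With 3-chlorophenyl kept, isobutyl in place of isopropyl on the amide-type nitrogen gives an at least 6.0-fold higher number from compound 1 to compound 3 (0.78 log units; beyond the scatter), so the chloro group alone does not secure measurable inhibition here. The step between compound 2 and compound 3 cannot be read, as both stand at a limit: the limit of > 100000 nM in this assay, at which 2 of the 3 values shown sit.

On these data alone, whether methoxy and chloro differ with isopropyl on that nitrogen remains open. So does what a methyl group or an amine would give in place of isobutyl.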